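Triazole nitrogen substituent swap in a chromene ester series

The source may report more compounds than this note shows. Statements on the series, on what has been measured and on what is new or still open speak of the compounds shown alone.

Working notes on a small set sharing the core of compound 1 `CCOC(=O)C1=Cc2ccccc2OC1(OCc1cn(CC(=O)Nc2ccc(C)cc2)nn1)C(F)(F)F`. Going by the values given here, in a functional assay on HeLa cells (Homo sapiens) for inhibition, read by MTT assay, with a stated time of 24 h (a higher number here means a weaker inhibitor, a lower number a stronger inhibitor), compound 1 gives 67400 nM, and this is the only value in the set that is a number. Compound 2 `CCOC(=O)C1=Cc2ccccc2OC1(OCc1cc(-c2ccc([N+](=O)[O-])cc2)no1)C(F)(F)F` is reported only as a limit in this assay, > 150000 nM. Among the compounds with values here, the set therefore holds one measured number and one limit (the limit of > 150000 nM in this assay, at which 1 of the 2 values shown sits), and no step between two measured compounds can be drawn from it.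

Compound 3 `CCOC(=O)C1=Cc2ccccc2OC1(OCc1cn(-c2ccc(F)c(Cl)c2)nn1)C(F)(F)F` is not yet measured in this assay. It differs from compound 1 in one place 3-chloro-4-fluorophenyl in place of ((4-methylphenyl)carbamoyl)methyl on an aromatic nitrogen. Within the data shown here, the record gives no measured step of this kind, so no direction can be read off for it.

Expectation for compound 3 rests on compound 1 alone, whose value 67400 nM is the one anchor. The expected step of a 1.0-fold higher number from compound 1 to compound 3 (0.02 log units; within the scatter) is taken as no more than the scatter of the method, in no set direction. Compound 3 is estimated at 70000 nM in this assay, with a range from 20000 nM to 200000 nM.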

Compound 3, half-maximal inhibitory concentration: 22700 nM
The estimate for compound 3 lay 3.1-fold (0.49 log units) above the measured number, within the range that was stated.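

In this assay, going by these compounds alone, replacing ((4-methylphenyl)carbamoyl)methyl with 3-chloro-4-fluorophenyl on the aromatic nitrogen of the five-membered aromatic ring with 3 nitrogen gives the first measured step at this position: a 3.0-fold lower number from compound 1 to compound 3 (0.47 log units; beyond the scatter). The change removes the amide along with the hydrogen-bond donor and acceptor counted with it, yet the number still falls, so in this pair the ((4-methylphenyl)carbamoyl)methyl group is not required for the inhibition read here. Nothing shown gives a measured cause for this step.

The change alters the chain, the substituents on the aromatic ring and the halogens all at once, so the compounds shown cannot assign the step to any one of these parts, and an unsubstituted phenyl, a 4-fluorophenyl or a 3-chlorophenyl on this nitrogen would be needed to separate them. Within the data shown here, compound 2 is a limit and not a number, so no step to it can be read: the limit of > 150000 nM in this assay, at which 1 of the 3 values shown sits.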